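A few compounds are considered here, and "the series" means these few. Any claim that something is new, unique, unknown or untested is made for them only; others in the source may bear on it.

Compound 3 `O=C(O)c1ccc(-c2cnc(C(=O)CCc3ccc(-c4ccccc4)cc3)o2)cn1`, whose ring bears a 6-carboxypyridin-3-yl group, gives 44 nM in an assay for inhibition of Fatty-acid amide hydrolase 1 (Rattus norvegicus) (a lower number here means a stronger inhibitor, a higher number a weaker inhibitor), the highest of the three numbers measured. Compound 1 `COC(=O)c1ccc(-c2cnc(C(=O)CCc3ccc(-c4ccccc4)cc3)o2)cn1` gives 0.6 nM in this assay, and compound 2 `O=C(CCc1ccc(-c2ccccc2)cc1)c1ncc(C(=O)C(F)(F)F)o1` gives 8 nM. The step from the methyl ester to the free acid is a 73-fold higher number from compound 1 to compound 3 (1.87 log units; beyond the scatter), and exchanging the trifluoromethyl carbonyl for the carboxypyridinyl group is a 5.5-fold higher number from compound 2 to compound 3 (0.74 log units; beyond the scatter), so the acid stands weakest among these compounds.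

Compound 4 `CN(C)C(=O)c1cnc(C(=O)CCc2ccc(-c3ccccc3)cc2)o1` differs from compound 3 in one place: dimethylcarbamoyl in place of 6-carboxypyridin-3-yl on an aromatic carbon. Among the compounds with values here, no measured step covers exactly this exchange. What bears on it is that the two neutral groups at this position, in compound 1 and compound 2, both gave far lower numbers than the acid of compound 3, and that compound 2 shows a small group without a ring can still give a low number. A neutral dimethylcarbamoyl group is therefore expected to move the number down, by about an 8.8-fold lower number from compound 3 to compound 4 (0.94 log units; beyond the scatter). Compound 4 is estimated at 5 nM, between 1 nM and 30 nM.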

Compound 4, inhibition constant: 3 nM
Compound 4: middle estimate off by 1.7-fold (0.22 log units), on the high side; the range from low to high includes it.
By their numbers in this assay, from the lowest: compound 1; then compound 4; then compound 2; then compound 3.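

In this assay, exchanging the 6-carboxypyridin-3-yl group for dimethylcarbamoyl gives a 15-fold lower number from compound 3 to compound 4 (1.17 log units; beyond the scatter), so a group with no ring and fewer heavy atoms can sit at this place and still give a far lower number than the acid. Compound 2 already had no ring here, yet dimethylamino in place of trifluoromethyl on the same carbonyl carbon gives a 2.7-fold lower number from compound 2 to compound 4 (0.43 log units; beyond the scatter), so what the carbonyl carries also matters. The ring is not required, but the 6-(methoxycarbonyl)pyridin-3-yl group remains the best of the four, as a 5.0-fold higher number from compound 1 to compound 4 (0.70 log units; beyond the scatter) shows.

No measurement shown explains why the groups fall in this order. Still open, on these data alone, is how a carboxylic acid attached directly at this place, with no ring, or a longer chain on the amide nitrogen would compare.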